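Para-substituent swap on the 8-aryl group of compound 1

This account rests on a few compounds, and the source may have more. Where it says the series, first, only, none or still open, it means among the compounds named here.

Among the measured compounds shown here, compound 1 `Cn1c(=O)c2nc(-c3ccc([N+](=O)[O-])cc3)[nH]c2n(C)c1=O` is the weakest binder among the three measured members: in an assay for binding affinity to adenosine receptor A1 (Bos taurus) (a lower number here means a stronger inhibitor, a higher number a weaker inhibitor), compound 1 gives 8 nM. Compound 3 `Cn1c(=O)[nH]c2[nH]c(-c3ccccc3)nc2c1=O`, which carries an unsubstituted phenyl ring on a related core, gives 2.5 nM in this assay, a stronger result that lies beyond the usual scatter. Compound 2 `CCCn1c(=O)c2nc(-c3ccc(Cl)cc3N)[nH]c2n(CCC)c1=O`, with longer chains on the core and a substituted aryl ring, gives 0.05 nM in this assay and is by far the strongest of the three.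

Compound 4 `CN(C)c1ccc(-c2nc3c(=O)n(C)c(=O)n(C)c3[nH]2)cc1` is the next point to fix. It differs from compound 1 in a single place: dimethylamino in place of nitro on an aromatic carbon. For the measured compounds named here, no step between two measured compounds covers this kind of change, so the size of the move has to be estimated from the spread of the measured values alone. Compound 3 shows that the aryl ring tolerates the loss of the nitro group without harm, so a move in the direction of stronger binding is plausible, though a step of no more than the scatter would not surprise.

For compound 4 a value of 4 nM is expected, with a range from 1 nM to 20 nM, a step from compound 1 of a 2.0-fold lower number from compound 1 to compound 4 (0.30 log units; within the scatter).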

Compound 4, half-maximal inhibitory concentration: 1.8 nM
Beside the measured number, compound 4's estimate is 2.2-fold (0.35 log units) above it; low and high end bracket the measured number.
By their numbers in this assay, from the lowest: compound 2; then compounds 4 and 3 (each within the scatter of the next); then compound 1.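

In this assay, among the compounds shown here, dimethylamino in place of nitro on the aromatic carbon para to a large group gives a 4.4-fold lower number from compound 1 to compound 4 (0.65 log units; beyond the scatter) on an otherwise unchanged core, the first step that isolates a single change at this position. The position therefore responds to the identity of its substituent, and the direction of the step favours dimethylamino over nitro, though this pair alone gives only a modest step and no trend. The two groups hold the same number of heavy atoms and neither holds a ring, so that count does not separate them, and no measurement on hand accounts for the step.

Open, going by these compounds, is whether a plain amine, a methoxy group or a chlorine at this place on the shared core would give a number close to that of compound 1 or close to that of compound 4. Also open, on these data alone, is whether the same swap gives a step of similar size on a core carrying longer chains, such as propyl, in place of the methyl groups.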